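A few compounds are considered here, and "the series" means these few. Any claim that something is new, unique, unknown or untested is made for them only; others in the source may bear on it.

Measured so far in an assay on isolated protein for displacement of a labelled ligand from cathepsin S (Homo sapiens), read by fluorescence; a lower number here means tighter binding, a higher number weaker binding: compound 1 `CC(C)(C)C[C@H](NC(=O)N1CCOCC1)C(=O)N[C@H](C#N)CCc1ccccc1`, 0.9 nM; compound 2 `CC(C)(C)C[C@H](NC(=O)N1CCOCC1)C(=O)N[C@H](C#N)COCc1ccccc1`, 0.6 nM; compound 3 `Cc1ccccc1COC[C@@H](C#N)NC(=O)[C@H](CC(C)C)NC(=O)N1CCOCC1`, 3 nM.

Compound 3 gives the highest of the three numbers, with compound 1 nearest and compound 2 furthest, both gaps beyond the scatter. Compound 4 `Cc1ccccc1COC[C@@H](C#N)NC(=O)[C@H](CC(C)(C)C)NC(=O)N1CCOCC1` differs from compound 3 by methyl in place of hydrogen on a saturated chain carbon bound to three saturated chain carbons. Among the compounds with values here, the only measured step, a 1.5-fold lower number from compound 1 to compound 2 (0.18 log units; within the scatter), concerns another part of the molecule and does not bear on this change; no measured pair isolates the added methyl. Compounds 1 and 2 both carry the neopentyl chain and both give lower numbers than compound 3, though each differs from compound 3 in more than one place. A lower number in this assay is therefore expected for compound 4, a step of a 3.0-fold lower number from compound 3 to compound 4 (0.48 log units; beyond the scatter). Compound 4 is estimated at 1 nM, range 0.4 nM to 3 nM.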

Compound 4, dissociation constant: 0.3 nM
Compound 4: middle estimate off by 3.3-fold (0.52 log units), on the high side; measured number below the stated range.
By their numbers in this assay, from the lowest: compounds 4, 2 and 1 (each within the scatter of the next, the first and the last beyond it); then compound 3.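

Isobutyl to neopentyl now has a matched pair in this assay (a 10-fold lower number from compound 3 to compound 4 (1.00 log units; beyond the scatter)), so the added methyl on a saturated chain carbon bound to three saturated chain carbons counts on its own, beyond the scatter. Methyl in place of hydrogen on an aromatic carbon stays within the scatter (a 2.0-fold lower number from compound 2 to compound 4 (0.30 log units; within the scatter)), although (2-methylbenzyl)oxy in place of benzyl gives a step beyond it (a 3.0-fold lower number from compound 1 to compound 4 (0.48 log units; beyond the scatter)). No measurement to hand accounts for these steps.

Open: how a cyclohexylmethyl group in place of neopentyl would read in this assay, and whether the isobutyl to neopentyl step holds without the methyl on the aromatic carbon.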